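Thiazole to Oxazole on the Carbonyl of Compound 3

The source may report more compounds than this note shows. Statements on the series, on what has been measured and on what is new or still open speak of the compounds shown alone.

Compound 1 `CCCCNc1nc(N)nc2c1CN(Cc1ccccc1Cl)CC2` carries a 2-chlorobenzyl group on an amine nitrogen in a ring and, in an assay on HEK293 cells for agonist activity at Toll-like receptor 8 (Homo sapiens), read by a luciferase reporter, with a stated time of 6 h (a lower number here means that less compound is needed, a higher number that more compound is needed for the effect), gives 0.05 uM. Replacing that group with cyclobutylcarbonyl gives compound 2 `CCCCNc1nc(N)nc2c1CN(C(=O)C1CCC1)CC2`, which shows 0.4 uM, and replacing it with (1,3-thiazol-4-yl)carbonyl gives compound 3 `CCCCNc1nc(N)nc2c1CN(C(=O)c1cscn1)CC2`, which shows 0.5 uM. The steps are an 8.0-fold higher number from compound 1 to compound 2 (0.90 log units; beyond the scatter) and a 10-fold higher number from compound 1 to compound 3 (1.00 log units; beyond the scatter), while between the two carbonyl compounds the step is a 1.3-fold higher number from compound 2 to compound 3 (0.10 log units; within the scatter). Compound 3 thus has the highest of the three numbers, but compound 2 lies within the scatter of it; only compound 1 stands beyond.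

Compound 4 `CCCCNc1nc(N)nc2c1CN(C(=O)c1cocn1)CC2` differs from compound 3 by 1,3-oxazol-4-yl in place of 1,3-thiazol-4-yl on a carbonyl carbon. Within the data shown here, the one measured step that bears on this place is a 1.3-fold higher number from compound 2 to compound 3 (0.10 log units; within the scatter), an exchange of the whole ring on the carbonyl carbon that left the number within the scatter; the larger steps from compound 1 concern the loss of 2-chlorobenzyl and do not address this change. Swapping one five-membered aromatic ring with 2 hetero atoms for another is therefore expected to move the number little, an expected no change at the digits printed from compound 3 to compound 4 (within the scatter) in this assay. Compound 4 is estimated at 0.5 uM, in the range 0.2 uM to 1.2 uM.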

Compound 4, minimum effective concentration: 0.2 uM
Compound 4: middle estimate off by 2.5-fold (0.40 log units), on the high side; the measured number falls inside the stated range.
By their numbers in this assay, from the lowest: compound 1; then compounds 4, 2 and 3 (each within the scatter of the next, the first and the last beyond it).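

In this assay the exchange on the carbonyl carbon now gives a step beyond the scatter, a 2.5-fold lower number from compound 3 to compound 4 (0.40 log units; beyond the scatter), even though 1,3-oxazol-4-yl and 1,3-thiazol-4-yl differ only in oxygen for sulfur and match in every count given. The comparison with cyclobutyl at the same place, a 2.0-fold lower number from compound 2 to compound 4 (0.30 log units; within the scatter), stays within the scatter, while the 2-chlorobenzyl compound remains apart, with a 4.0-fold higher number from compound 1 to compound 4 (0.60 log units; beyond the scatter) as the step. Nothing shown here gives a reason for the difference between the two rings.

As far as these compounds go, whether an imidazole ring, a pyridine ring or a phenyl ring on the carbonyl carbon would stand with the oxazole or with the thiazole remains open. So does whether a benzyl group without the chlorine would keep the low number of compound 1.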